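Chloro Placement on the Shared Core: Paw Edema Notes

The source may report more compounds than this note shows. Statements on the series, on what has been measured and on what is new or still open speak of the compounds shown alone.

Of the compounds shown here, two have numbers so far. Compound 1 `N#Cc1c(Nc2ccc(Cl)cc2)nc(SCC(=O)Nn2c(COc3ccc(Cl)cc3Cl)nc3ccccc3c2=O)nc1-c1ccccc1` carries a chloro group on its anilino ring, and in a functional assay on the whole organism (strain albino) for inhibition, with Rattus norvegicus as the target, read by paw edema, with a stated time of 1 h, at a dose of 100 mg/kg by the oral route (on this read-out lower numbers stand for less inhibition and higher numbers for more inhibition at the one dose given (going by the name of the read-out)), compound 1 gives 54.6%. Compound 2 `N#Cc1c(Nc2ccccc2)nc(SCC(=O)Nn2c(COc3ccc(Cl)cc3Cl)nc3ccccc3c2=O)nc1-c1ccc(Cl)cc1` carries the chloro group on the other phenyl ring instead, and in this assay compound 2 gives 43.6%, the lower of the two numbers, with compound 1 standing higher by a gap beyond the scatter. For the measured compounds named here, no measured pair differs in a single place, so no step within the measured set can be read directly. Compound 3 `N#Cc1c(Nc2ccc(Cl)cc2)nc(SCC(=O)Nn2c(COc3ccc(Cl)cc3Cl)nc3ccccc3c2=O)nc1-c1ccc(Cl)cc1` combines both chloro groups; it differs from compound 2 by chloro in place of hydrogen on an aromatic carbon. The expected step here is a number 6.4 percentage points higher from compound 2 to compound 3 (within the scatter), a modest gain in inhibition that may not exceed the scatter. Compound 3 is expected to give 50% in this assay, within a range from 36% to 63%.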

Compound 3, a percentage reported as inhibition, in the whole organism at one dose (the size of the read-out at that dose, not a potency): 54.6%
Beside the measured number, compound 3's estimate is 4.6 percentage points below it; the measured number falls inside the stated range.
By their numbers in this assay, from the lowest: compound 2; then compounds 1 and 3 (each within the scatter of the next).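

In this assay the first single-place steps can now be read, and a number 11 percentage points higher from compound 2 to compound 3 (beyond the scatter) follows the change from anilino to (4-chlorophenyl)amino, with the 4-chlorophenyl group present in both compounds. By contrast, no change at the digits printed from compound 1 to compound 3 (within the scatter) follows the change from phenyl to 4-chlorophenyl, with the (4-chlorophenyl)amino group present in both compounds, so in this pair of steps only the chloro on the anilino ring goes with a step beyond the scatter. No measured data bear on why the two chloro changes give different steps.

Going by these compounds, whether a methoxy group or an amine in place of this chloro would give a step of similar size remains open. For the compounds shown here, also open is whether the anilino step would hold with other groups on the shared core, since only one such pair can be read here.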